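The source may report more compounds than this note shows. Statements on the series, on what has been measured and on what is new or still open speak of the compounds shown alone.

Compound 1 `COc1cccc(C(C)Sc2nc3c(cnn3C)c(=O)n2-c2ccccc2)c1` gives 174 nM in an assay on isolated protein for inhibition of Retinaldehyde dehydrogenase 3 (Homo sapiens); on this read-out lower numbers stand for stronger inhibition and higher numbers for weaker inhibition.
Compound 2 `Cn1ncc2c(=O)n(-c3ccccc3)c(COc3cccc(F)c3)nc21` gives 780 nM in this assay.
Compound 3 `O=c1c2cncn2nc(SCc2cccc(F)c2)n1-c1ccccc1` gives 500 nM in this assay.

Among these three, compound 1 stands lowest, and hence strongest, in this assay. Compound 3 comes nearest to it, with a number that already lies beyond the scatter, and compound 2 lies furthest away. For the measured compounds named here, no pair among the measured compounds differs in only one place, so no single-point step is available from them.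

Compound 4 `CC(Sc1nc2c(cnn2C)c(=O)n1-c1ccccc1)c1cccnc1` has not yet been measured. It differs from compound 1 in one place: pyridin-3-yl in place of 3-methoxyphenyl on a saturated chain carbon bound to a saturated chain carbon and a sulfur. The place of the change stays the same, a saturated chain carbon bound to a saturated chain carbon and a sulfur. Going by the values given here, nothing among the measured compounds tests this exchange, so the expectation rests on compound 1 alone. A modest weakening is expected, a step of about the size of the usual scatter or a little beyond it, a 2.0-fold higher number from compound 1 to compound 4 (0.30 log units; within the scatter). Compound 4 is therefore estimated at 350 nM in this assay, with a range from 120 nM to 1000 nM.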

Compound 4, half-maximal inhibitory concentration: 95 nM
For compound 4 the middle estimate is 3.7-fold (0.57 log units) above the measured one; measured number below the stated range.
By their numbers in this assay, from the lowest: compounds 4 and 1 (each within the scatter of the next); then compounds 3 and 2 (each within the scatter of the next).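

In this assay, pyridin-3-yl in place of 3-methoxyphenyl on a saturated chain carbon bound to a saturated chain carbon and a sulfur gives a 1.8-fold lower number from compound 1 to compound 4 (0.26 log units; within the scatter), so the two compounds cannot be told apart on this read-out. For the compounds shown here, this first single-place comparison shows that the position tolerates the exchange of a carbon-only ring carrying a methoxy group for a six-membered aromatic ring with 1 hetero atom, a change the earlier compounds did not test. No measurement shown gives a reason for this result.

From the compounds shown here alone, whether pyridin-4-yl, or a phenyl ring carrying an amine or a carboxylic acid, would also stay within the scatter of compound 1 at this place remains open. Going by these compounds, it is also open whether pyridin-3-yl would behave the same way on the frameworks of compound 2 and compound 3.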